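Isothiocyanate-bearing anilino series: compound 4 from compound 1

A few compounds are considered here, and "the series" means these few. Any claim that something is new, unique, unknown or untested is made for them only; others in the source may bear on it.

Measured so far:
compound 1, `CN(C)C(=O)c1cc2cnc(Nc3ccc(S(=O)(=O)NCCCN=C=S)cc3)nc2n1C1CCCC1`, 72.8% in a functional assay on NCI-H1299 cells (Homo sapiens) for inhibition, read by CCK-8 assay, with a stated time of 72 h, tested at 10 uM; a higher number here means a stronger effect of the compound at the concentration tested, a lower number a weaker effect
compound 2, `CN(C)C(=O)c1cc2cnc(Nc3ccc(C(=O)NCCCCCN=C=S)cc3F)nc2n1C1CCCC1`, 86.7% in this assay
compound 3, `CN(C)C(=O)c1cc2cnc(Nc3ccc(C(=O)NCCCCCCCN=C=S)cc3F)nc2n1C1CCCC1`, 35.8% in this assay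

On these three numbers compound 1 stands second highest: compound 2 lies above it by a margin beyond the scatter, and compound 3 lies well below it, also beyond the scatter.

Compound 4, `CN(C)C(=O)c1cc2cnc(Nc3ccc(NC(=O)CCCCCCN=C=S)cc3)nc2n1C1CCCC1`, has not yet been measured in this assay. It differs from compound 1 in one place: a group of 12 heavy atoms (8 carbon, 2 nitrogen, 1 oxygen, 1 sulfur; no ring) in place of a group of 10 heavy atoms (4 carbon, 2 nitrogen, 2 oxygen, 2 sulfur; no ring), on an aromatic carbon. The group that enters is an amide-linked chain ending in the isothiocyanate; the group that leaves is the sulfonamide-linked chain ending in the same isothiocyanate.

Within the data shown here, one measured step bears on this: a number 50.9 percentage points lower from compound 2 to compound 3 (beyond the scatter), where a longer chain between the linker and the isothiocyanate went with a large loss of inhibition. Among the measured compounds shown here, compound 4 carries a longer chain than compound 1, so a fall is expected in this assay, though the linker itself also changes here and no measured pair separates those two effects. The expected step is a number 27.8 percentage points lower from compound 1 to compound 4 (beyond the scatter).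

For compound 4 the estimate is 45%, with a range of 20% to 72%.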

Compound 4, a percentage reported as inhibition, at one concentration (the size of the read-out at that concentration, not a potency): 80.9%
The estimate for compound 4 lay 35.9 percentage points below the measured number; measured number outside the range, above it.
By their numbers in this assay, from the lowest: compound 3; then compounds 1, 4 and 2 (each within the scatter of the next, the first and the last beyond it).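

In this assay, replacing the sulfonamide-linked chain with the larger amide-linked chain on this aromatic carbon, para to a large group, gives a number 8.1 percentage points higher from compound 1 to compound 4 (within the scatter), so the two groups cannot be told apart here. This shows that inhibition at the tested concentration holds up with either linker and that a larger chain-bearing group at this position does not in itself go with a loss; the large fall seen as a number 50.9 percentage points lower from compound 2 to compound 3 (beyond the scatter), on a saturated chain carbon of a different parent, therefore does not carry over as a general rule to this change. Nothing at hand accounts for this outcome.

Linker type and chain length change together in this step, so their separate contributions remain unresolved, and the same chain on a sulfonamide link, or a longer chain on the amide link of compound 4, would pull them apart. Equally open, on these data alone, is what the chain end contributes, which an amine or a carboxylic acid in place of the isothiocyanate would address.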